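The source may hold more compounds than are shown below. What is called first, only, known or untested is meant among the compounds shown, and "the series" means these compounds.

Within the data shown here, the three compounds measured so far share one core and differ only in the length of a chain on a saturated chain carbon bound to an aromatic carbon. Compound 1 `CCCCCCCCc1ccc(NC(=O)Nc2c(C(C)C)cccc2C(C)C)cc1` gives 11 nM in an assay on isolated protein for inhibition of acyl-CoA:cholesterol acyltransferase (Oryctolagus cuniculus); a higher number here means a weaker inhibitor, a lower number a stronger inhibitor. Compound 3 `CCCCCCCc1ccc(NC(=O)Nc2c(C(C)C)cccc2C(C)C)cc1` gives 19 nM in this assay, and compound 2 `CCCCCCc1ccc(NC(=O)Nc2c(C(C)C)cccc2C(C)C)cc1` gives 26 nM. Compound 2 has the highest number of the three: its nearest neighbour is compound 3, with a 1.4-fold lower number from compound 2 to compound 3 (0.14 log units; within the scatter), and the furthest is compound 1, with a 2.4-fold higher number from compound 1 to compound 2 (0.37 log units; beyond the scatter). The step of a 1.7-fold higher number from compound 1 to compound 3 (0.24 log units; within the scatter) is the other comparison that bears on chain length.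

Compound 4 `Cc1ccc(NC(=O)Nc2c(C(C)C)cccc2C(C)C)cc1` is not yet measured. Relative to compound 2 the change is hydrogen in place of pentyl on a saturated chain carbon bound to an aromatic carbon. The three measured steps all point the same way as the chain shortens, with only a 2.4-fold higher number from compound 1 to compound 2 (0.37 log units; beyond the scatter) beyond the scatter, and the change to compound 4 removes far more of the chain than any of them. Among the measured compounds shown here, a rise in the number, larger than any step seen so far, is therefore expected, though the data hold no compound with so short a chain and the size is uncertain. Compound 4 is estimated to give 250 nM in this assay, between 80 nM and 800 nM, which means an expected step of a 9.6-fold higher number from compound 2 to compound 4 (0.98 log units; beyond the scatter).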

Compound 4, half-maximal inhibitory concentration: 250 nM
The estimate for compound 4 equals the measured number at the digits printed, within the range that was stated.
By their numbers in this assay, from the lowest: compounds 1, 3 and 2 (each within the scatter of the next, the first and the last beyond it); then compound 4.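

Shortening the chain on the saturated chain carbon bound to an aromatic carbon down to the methyl of compound 4 has a far larger effect in this assay than any change among the longer chains: hydrogen in place of pentyl gives the first step (a 9.6-fold higher number from compound 2 to compound 4 (0.98 log units; beyond the scatter)), hydrogen in place of hexyl a larger one (a 13-fold higher number from compound 3 to compound 4 (1.12 log units; beyond the scatter)), and hydrogen in place of heptyl the largest (a 23-fold higher number from compound 1 to compound 4 (1.36 log units; beyond the scatter)). Among the earlier compounds only one step lay beyond the scatter (a 2.4-fold higher number from compound 1 to compound 2 (0.37 log units; beyond the scatter)), so they showed little sensitivity to chain length, whereas compound 4 shows that this position does not tolerate losing most of the chain. The data shown offer no measurement that accounts for this rise.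

From the compounds shown here alone, what an ethyl, propyl or butyl chain would give at this position remains open, so the chain length at which the number begins to climb cannot be placed within the wide gap between compound 4 and compound 2. Also open, going by these compounds, is whether a longer chain, or a chain ending in an amine or a carboxylic acid, would keep the number near that of compound 1.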